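The compounds below may be only part of what the source reports. "The series", "measured", "known", "first", "only" and "open" are said of these compounds alone.

Compound 1 `C=C1[C@H](OC(C)=O)[C@@H](OC(C)=O)[C@@H](OC(C)=O)C(C)(C)/C=C/[C@H](C)[C@H](OC(=O)c2ccccc2)[C@@]2(O)C[C@@](C)(O)[C@H](OC(C)=O)[C@@H]2[C@H]1OCC(C)C` and compound 2 `C=C1[C@H](OC(C)=O)[C@@H](OC(=O)c2cccc(C)c2)[C@@H](OC(C)=O)C(C)(C)/C=C/[C@H](C)[C@H](OC(=O)c2ccccc2)[C@@]2(O)C[C@@](C)(O)[C@H](OC(C)=O)[C@@H]2[C@H]1OCC(C)C` share one core. In a functional assay on MCF7 cells (Homo sapiens) for antiproliferative activity, read by MTT assay, with a stated time of 48 h (on this read-out higher numbers stand for weaker inhibition and lower numbers for stronger inhibition), compound 1 gives only a limit of the assay, > 100000 nM. In this assay compound 2 gives 23400 nM. The change 3-methylphenyl in place of methyl on a carbonyl carbon thus produced an at least 4.2-fold lower number from compound 1 to compound 2 (0.63 log units; beyond the scatter). Compound 3 `C=C1[C@H](OC(C)=O)[C@@H](OC(C)=O)[C@@H](OC(C)=O)C(C)(C)/C=C/[C@H](C)[C@H]2O[C@]3(C)C[C@@]2(OC(=O)c2ccccc2)[C@H]([C@H]3OC(C)=O)[C@H]1OCC(C)C` is built on a second core; the difference between the two cores is not broken down here. In this assay compound 3 likewise gives only a limit of the assay, > 100000 nM. Relevant evidence for the measured steps is the limit of > 100000 nM in this assay, at which 2 of the 3 values shown sit. Compound 4 `C=C1[C@H](OC(C)=O)[C@@H](OC(=O)c2cccc(C)c2)[C@@H](OC(C)=O)C(C)(C)/C=C/[C@H](C)[C@H]2O[C@]3(C)C[C@@]2(OC(=O)c2ccccc2)[C@H]([C@H]3OC(C)=O)[C@H]1OCC(C)C` carries the same change on the core of compound 3, (3-methylphenyl in place of methyl on a carbonyl carbon), at a place described in the same words as before. From compound 3 to compound 4 a step of similar size is expected, an at least 2.5-fold lower number from compound 3 to compound 4 (0.39 log units; beyond the scatter), resting on the measured step of an at least 4.2-fold lower number from compound 1 to compound 2 (0.63 log units; beyond the scatter). Since compound 3 sits at a limit, the value expected for compound 4 in this assay is 40000 nM, within 8000 nM to 150000 nM.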

Compound 4, half-maximal inhibitory concentration: > 100000 nM
Compound 4 was reported as a limit; the forecaster's own chance of this, stated with the estimate: 45%; middle value at least 2.5-fold (0.39 log units) from the limit.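

In this assay compound 4 gives only a limit, > 100000 nM. For the compounds shown here, with compound 3 also at a limit, no step from compound 3 to compound 4 can be read. Still open, going by these compounds, is whether 3-methylphenyl in place of methyl on a carbonyl carbon lowers the number at all on the core of compound 3.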